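Trifluoromethyl for Fluoro: What Compound 4 May Show

The compounds below may be only part of what the source reports. "The series", "measured", "known", "first", "only" and "open" are said of these compounds alone.

Compound 1, `CCC(C(=O)N1CCN(c2cccc(F)c2)CC1)N1C(=O)CCC1=O`: 75%
Compound 2, `CC(C(=O)N1CCN(c2ccc(C(F)(F)F)cc2)CC1)N1C(=O)CCC1=O`: 25%
Compound 3, `CC(C(=O)N1CCN(c2ccc(F)cc2)CC1)N1C(=O)CCC1=O`: 100%

All three were tested in a functional assay on the whole organism (strain Swiss) with Mus musculus as the target, in the maximal electroshock model, with a stated time of 0.25 h, at a dose of 300 mg/kg by the intraperitoneal route; a lower number here means a weaker effect, a higher number a stronger effect of the compound at the dose given. Compound 3 and compound 2 differ in one place: trifluoromethyl in place of fluoro on an aromatic carbon. That step is a number 75 percentage points lower from compound 3 to compound 2 (beyond the scatter). Compound 1 and compound 3 resemble each other, but the difference between the two cores is not broken down here. Compound 4, `CCC(C(=O)N1CCN(c2cccc(C(F)(F)F)c2)CC1)N1C(=O)CCC1=O`, is not yet measured; it differs from compound 1 by trifluoromethyl in place of fluoro on an aromatic carbon. This is the same kind of change, not the same one: in compound 2 the entering group sits para to a large group, in compound 4 meta to a large group. A fall of similar size is expected because a number 75 percentage points lower from compound 3 to compound 2 (beyond the scatter) shows what this kind of change did once, though a single example from a different place gives little certainty. The expected step is a number 50 percentage points lower from compound 1 to compound 4 (beyond the scatter). Compound 4 is therefore estimated at 25%, most likely between 0% and 75%.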

Compound 4, a percentage reported as activity, at one dose (the size of the read-out at that dose, not a potency): 75%
For compound 4 the middle estimate is 50 percentage points below the measured one; low and high end bracket the measured number.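

In this assay, trifluoromethyl in place of fluoro now gives no change at the digits printed from compound 1 to compound 4 (within the scatter). Set beside the earlier case, the effect of this change did not carry over from one core to the other: the same change on two cores in this assay, a number 75 percentage points lower (beyond the scatter) from compound 3 to compound 2 and no change at the digits printed (within the scatter) from compound 1 to compound 4, 75 percentage points apart, beyond the scatter of two such steps. This does not show what lies behind the gap, as the two pairs differ both in their cores and in where the group sits on the aromatic ring, and these two differences cannot be separated here.

The compounds shown leave open how a chloro or methoxy group would read in the same place on the core of compound 1. They also leave open whether the two cores would still differ with trifluoromethyl in one shared place.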